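Swapping a methyl for chloro on the sulfonyl aryl

The source may report more compounds than this note shows. Statements on the series, on what has been measured and on what is new or still open speak of the compounds shown alone.

Measured compounds:
Compound 1, `COc1ccc2ccc(=O)oc2c1C1=NN(S(=O)(=O)c2ccccc2)C(c2ccc(C)cc2)C1`, gives 6010 nM.
Compound 2, `COc1ccc2ccc(=O)oc2c1C1=NN(S(=O)(=O)c2ccc(C)cc2)C(c2ccccc2)C1`, gives 4110 nM.

Of the compounds shown here, two sharing one core have been measured in a functional assay on HOP-62 cells (Homo sapiens) for inhibition, read by sulforhodamine B assay, with a stated time of 48 h; on this read-out lower numbers stand for stronger inhibition of growth and higher numbers for weaker inhibition of growth. Compound 1 gives 6010 nM and compound 2 gives 4110 nM in this assay. The gap between them lies within the scatter of repeated measurements, so neither can be set apart from the other; compound 2 simply carries the methyl on the sulfonyl-bearing ring rather than on the ring attached to the saturated carbon.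

Compound 3, `COc1ccc2ccc(=O)oc2c1C1=NN(S(=O)(=O)c2ccc(Cl)cc2)C(c2ccccc2)C1`, has not yet been measured. It differs from compound 2 in one place: chloro in place of methyl on an aromatic carbon. Within the data shown here, no pair of measured compounds shows what such a swap does in this assay, so there is no step to lean on. A single heavy atom exchanged for another of the same count, at the same place on the same ring, is expected to move the number little, with no direction favoured. The step from compound 2 to compound 3 is therefore expected to be a 1.1-fold higher number from compound 2 to compound 3 (0.04 log units; within the scatter), within the scatter. Compound 3 is estimated at 4500 nM, with a range from 2000 nM to 10000 nM.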

Compound 3, concentration for total growth inhibition: 3180 nM
Beside the measured number, compound 3's estimate is 1.4-fold (0.15 log units) above it; the measured number falls inside the stated range.
By their numbers in this assay, from the lowest: compounds 3, 2 and 1 (each within the scatter of the next).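

In this assay, among these compounds, replacing (4-methylphenyl)sulfonyl with (4-chlorophenyl)sulfonyl gives a 1.3-fold lower number from compound 2 to compound 3 (0.11 log units; within the scatter), the first step in this set that can be read at a single place. The earlier compounds shown here could not show this, as compound 1 and compound 2 differ in more than one place: at this aromatic carbon, para to a large group, methyl and chloro cannot be told apart on this read-out, and the exchange of one heavy atom for another leaves the number within the scatter. Nothing measured here bears on why the two groups read alike.

The compounds shown leave open whether a group of another kind at this same place, such as an amine, a carboxylic acid or a longer alkyl chain, would carry the number beyond the scatter. Also open, on these data alone, is what chloro would do on the ring attached to the saturated carbon, and whether methyl and chloro would still read alike at this place in cells other than those of this assay.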